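Anilide series: cyano to nitro at the anilide para position

The source may report more compounds than this note shows. Statements on the series, on what has been measured and on what is new or still open speak of the compounds shown alone.

Measured:
compound 1 `COc1ccc(NC(=O)CS(=O)(=O)c2nccc(Oc3c(C)cc(C#N)cc3C)n2)cc1`, 5110 nM
compound 2 `Cc1cc(C#N)cc(C)c1Oc1ccnc(S(=O)(=O)CC(=O)Nc2ccc(C#N)cc2)n1`, >= 6010 nM

In an ADME assay on MT4 cells (Homo sapiens) for cytotoxicity, read by MTT assay, with a stated time of 4 days (a higher number here means that more compound is tolerated, a lower number that less compound is tolerated), compound 1 gives 5110 nM. For compound 2 the value >= 6010 nM is a limit of this assay, not a number, so compound 2 sits at the ceiling of the two measurements, as the limit of >= 6010 nM in this assay, at which 1 of the 2 values shown sits, records. Among the compounds with values here, the one measured step, an at least 1.1-fold higher number from compound 1 to compound 2 (0.07 log units; that floor lies within the scatter), lies within the scatter. Compound 3 `Cc1cc(C#N)cc(C)c1Oc1ccnc(S(=O)(=O)CC(=O)Nc2ccc([N+](=O)[O-])cc2)n1` carries nitro in place of cyano on an aromatic carbon. Within the data shown here, no measured step covers this change, so a step that the limit leaves unreadable from compound 2 to compound 3 is expected, no larger than the scatter. Compound 3 is estimated at 6500 nM, between 3000 nM and 15000 nM.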

Compound 3, half-maximal cytotoxic concentration: 59600 nM
Compound 3: the middle estimate sits 9.2-fold (0.96 log units) below what was measured; the measured number lies above the stated range.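

In this assay, this position now shows a change beyond the scatter: a 12-fold higher number from compound 1 to compound 3 (1.07 log units; beyond the scatter). The nitro group therefore tolerates more compound than methoxy here, whereas the floor for cyano in place of methoxy stayed within the scatter. Compound 2 gives only a limit, so its step to compound 3 cannot be read: the limit of >= 6010 nM in this assay, at which 1 of the 3 values shown sits.

Going by these compounds, whether compound 2 truly lies nearer compound 1 or compound 3 stays open. So does how an amine or a carboxylic acid at this position would read in this assay.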